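The source may hold more compounds than are shown below. What is called first, only, known or untested is meant among the compounds shown, and "the series" means these compounds.

Compounds measured in a functional assay on DU-145 cells (Homo sapiens) for inhibition, read by trypan blue exclusion, with a stated time of 96 h; on this read-out higher numbers stand for weaker inhibition of growth and lower numbers for stronger inhibition of growth:
compound 1, `COc1cc(/C=C(/Sc2ccc(Br)cc2)C(=O)c2ccc(Br)cc2)ccc1O`, 1000 nM;
compound 2, `O=C(O)c1ccc(C(=O)/C(=C\c2ccc(Cl)c([N+](=O)[O-])c2)SCc2ccc(Cl)cc2)cc1`, 1000 nM;
compound 3, `COc1ccccc1/C=C(/SCc1ccc(Cl)cc1)C(=O)c1ccc([N+](=O)[O-])cc1`, 10000 nM.

In this assay compound 1 stands level with compound 2 at the digits shown, and together the two give the lowest numbers of the three; compound 3 stands well beyond the scatter with its higher number. Compound 4, `O=C(/C(=C\c1ccc(Cl)cc1)Sc1ccc(Br)cc1)c1ccc(Br)cc1`, has not been measured. It differs from compound 1 in one place: 4-chlorophenyl in place of 4-hydroxy-3-methoxyphenyl on a double-bonded chain carbon bound to a double-bonded chain carbon. Among the measured compounds shown here, with no measured step of this kind among the compounds, and with compound 2 carrying a chlorinated ring at the same place and giving 1000 nM, the step of a 1.5-fold higher number from compound 1 to compound 4 (0.18 log units; within the scatter) is expected to stay within the scatter or lean slightly toward a higher number. Compound 4 is therefore estimated at 1500 nM, with a range from 400 nM to 6000 nM.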

Compound 4, concentration for 50% growth inhibition: 1000 nM
Compound 4: the middle estimate sits 1.5-fold (0.18 log units) above what was measured; the range from low to high includes it.
By their numbers in this assay, from the lowest: compounds 1, 2 and 4 (each within the scatter of the next); then compound 3.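

Replacing 4-hydroxy-3-methoxyphenyl with 4-chlorophenyl on a double-bonded chain carbon bound to a double-bonded chain carbon gives no change at the digits printed from compound 1 to compound 4 (within the scatter) in this assay and so shows that this position accepts the change. The hydroxy and methoxy groups can leave, and with them the hydrogen-bond donor and acceptors counted on that ring, without a shift beyond the scatter. Nothing offered here explains why the number holds.

It remains open whether the chlorine itself matters, since an unsubstituted phenyl ring does not appear among these compounds. On these data alone, how an amine on this ring, or a longer alkyl chain in its place, would fare also remains open.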